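A few compounds are considered here, and "the series" means these few. Any claim that something is new, unique, unknown or untested is made for them only; others in the source may bear on it.

Compound 1 `Cc1nc(-c2cccnc2)sc1-c1nnc(-c2ccc(Br)cc2)o1`: in an ADME assay on HCT-116 cells (Homo sapiens) for cytotoxicity, read by MTT assay (on this read-out lower numbers stand for higher toxicity in this test and higher numbers for lower toxicity in this test), compound 1 gives > 100 ug/mL, a limit of the assay and not a number.
Compound 2 `Cc1nc(-c2cccnc2)sc1-c1nnc(-c2ccccc2)o1`: in this assay compound 2 gives > 100 ug/mL, likewise a limit of the assay.

Among the compounds with values here, compound 2 therefore stands at the upper limit of this assay, and the only other value beside it is the same limit, so that the limit of > 100 ug/mL in this assay, at which 2 of the 2 values shown sit, describes everything measured so far. Within the data shown here, the one step between measured compounds, a step that the two limits leave unreadable from compound 1 to compound 2 (hydrogen in place of bromo on an aromatic carbon), cannot be sized, since both of its ends are limits.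

Compound 3 `Cc1nc(-c2cccnc2)sc1-c1nnc(-c2cccnc2)o1` has not been measured. It differs from compound 2 by pyridin-3-yl in place of phenyl on an aromatic carbon. Among the measured compounds shown here, no measured step bears on this change: the single step concerns a different position and is itself unreadable. The expectation for this assay is therefore no step beyond the scatter, with the result most likely to be reported again as a limit. Compound 3 is estimated at 150 ug/mL, within 60 ug/mL to 400 ug/mL. The expected step is a step that the limit leaves unreadable from compound 2 to compound 3.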

Compound 3, half-maximal cytotoxic concentration: > 100 ug/mL
Compound 3 gave a limit, no number; the forecaster's own chance of this, stated with the estimate: 80%; the middle value does not contradict the limit.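

No new step can be read from compound 2 to compound 3 or from compound 1 to compound 3, since all three compounds give only a limit, not a number, in this assay: the limit of > 100 ug/mL in this assay, at which 3 of the 3 values shown sit.

The compounds shown leave open whether 4-bromophenyl, phenyl and pyridin-3-yl differ at all in this read-out, and how far any of the three compounds lies from that limit.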